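Compound 3 to compound 4: one further methoxy

The source may hold more compounds than are shown below. What is called first, only, known or untested is meant among the compounds shown, and "the series" means these compounds.

In an ADME assay on CCRF-CEM cells (Homo sapiens) for antiproliferative activity, with a stated time of 48 h (a higher number here means a weaker inhibitor, a lower number a stronger inhibitor), compound 1 (`C=C(Br)C(=O)Nc1ccc(C(=O)/C=C/c2cc(OC)cc(OC)c2)cc1`) gives 2200 nM, compound 2 (`C=C(Br)C(=O)Nc1ccc(C(=O)/C=C/c2cc(OC)c(OC)c(OC)c2)cc1`) gives 330 nM, and compound 3 (`COc1cc(/C=C/C(=O)c2ccc(N)cc2)cc(OC)c1`) gives 5700 nM. Compound 3 thus has the highest number of the three. Its nearest neighbour is compound 1, with a 2.6-fold higher number from compound 1 to compound 3 (0.41 log units; beyond the scatter), where hydrogen stands in place of (1-bromoethenyl)carbonyl on the nitrogen.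

Compound 4 (`COc1cc(/C=C/C(=O)c2ccc(N)cc2)cc(OC)c1OC`) differs from compound 3 in one place: methoxy in place of hydrogen on an aromatic carbon. This is methoxy in place of hydrogen on an aromatic carbon, ortho to two methoxy groups and para to a large group.

The same exchange has a single measured precedent, a 6.7-fold lower number from compound 1 to compound 2 (0.82 log units; beyond the scatter). Among the compounds with values here, that pair carries (1-bromoethenyl)carbonyl on the nitrogen, whereas compound 4 carries hydrogen there, and no measured pair shows whether the exchange behaves alike with both. The other measured step only shows that this nitrogen substituent affects the number, so it gives no size for the present change. A step toward a lower number, beyond the scatter, is therefore expected, of roughly the precedent's size. The expected step is a 5.7-fold lower number from compound 3 to compound 4 (0.76 log units; beyond the scatter). For compound 4 the estimated value is 1000 nM, with an expected range of 350 nM to 3000 nM.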

Compound 4, half-maximal inhibitory concentration: 2300 nM
Compound 4: the middle estimate sits 2.3-fold (0.36 log units) below what was measured; measured number inside the range.
By their numbers in this assay, from the lowest: compound 2; then compounds 1 and 4 (each within the scatter of the next); then compound 3.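

With hydrogen on the nitrogen, methoxy in place of hydrogen, ortho to two methoxy groups and para to a large group, still lowers the number in this assay, a 2.5-fold lower number from compound 3 to compound 4 (0.39 log units; beyond the scatter), so the direction of the change holds with both nitrogen substituents, but its size does not carry over from one to the other: the same change on two cores in this assay, a 6.7-fold lower number (0.82 log units; beyond the scatter) from compound 1 to compound 2 and a 2.5-fold lower number (0.39 log units; beyond the scatter) from compound 3 to compound 4, 2.7-fold (0.43 log units) apart, beyond the scatter of two such steps

Read along the other axis, hydrogen in place of (1-bromoethenyl)carbonyl on the nitrogen raises the number further when this methoxy is present, a 7.0-fold higher number from compound 2 to compound 4 (0.84 log units; beyond the scatter), and the size of that step also depends on the partner group: the same change on two cores in this assay, a 2.6-fold higher number (0.41 log units; beyond the scatter) from compound 1 to compound 3 and a 7.0-fold higher number (0.84 log units; beyond the scatter) from compound 2 to compound 4, 2.7-fold (0.43 log units) apart, beyond the scatter of two such steps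

The methoxy and the nitrogen substituent therefore do not act as independent, additive changes across these four compounds.

Still open, from the compounds shown here alone, is whether the larger methoxy step needs the whole (1-bromoethenyl)carbonyl group or only an amide carbonyl, a question that an acetyl group on the nitrogen would address. Going by these compounds, it is also open whether an ethoxy or hydroxyl group on the same aromatic carbon would follow methoxy with either nitrogen substituent.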